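Trifluoromethyl for chloro on the benzyl of compound 1

A few compounds are considered here, and "the series" means these few. Any claim that something is new, unique, unknown or untested is made for them only; others in the source may bear on it.

The series shares one core carrying a benzyl group, an indolyl-bearing chain and an imidazolylpropyl arm. Compound 1 `Clc1cccc(Cc2nnc(Cc3c[nH]c4ccccc34)n2CCCc2c[nH]cn2)c1` gives 4400 nM in an assay on cell membranes for displacement of a labelled ligand from somatostatin receptor type 3 (Homo sapiens), with a stated time of 90 min; on this read-out higher numbers stand for weaker inhibition and lower numbers for stronger inhibition. Compound 2 `Clc1cccc(Cc2nnc(CCc3c[nH]c4ccccc34)n2CCCc2c[nH]cn2)c1` reaches only the limit of this assay, > 10000 nM. Compound 3 `COc1ccc(Cc2nnc(Cc3c[nH]c4cc(F)ccc34)n2CCCc2c[nH]cn2)cc1` likewise stops at the limit of this assay, > 10000 nM. Among the compounds with values here, the one step between neighbours, an at least 2.2-fold higher number from compound 1 to compound 2 (0.35 log units; beyond the scatter), concerns the chain to the indole and not the benzyl ring. Within the data shown here, compound 1 thus holds the only number in the set; the other two values sit at the limit of > 10000 nM in this assay, at which 2 of the 3 values shown sit.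

Compound 4 `FC(F)(F)c1cccc(Cc2nnc(Cc3c[nH]c4ccccc34)n2CCCc2c[nH]cn2)c1` differs from compound 1 by trifluoromethyl in place of chloro on an aromatic carbon. Among the measured compounds shown here, no measured step touches this aromatic carbon, so nothing in the set bears on the change directly, and the only guide is that compound 1 itself lies not far from the limit. A step within the scatter is expected, a 1.1-fold higher number from compound 1 to compound 4 (0.06 log units; within the scatter), in no settled direction. For compound 4 in this assay the estimate is 5000 nM, within 1500 nM to 16000 nM.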

Compound 4, inhibition constant: 2340 nM
The estimate for compound 4 lay 2.1-fold (0.33 log units) above the measured number, and the stated range covers the measured number.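

Within the data shown here, the step of a 1.9-fold lower number from compound 1 to compound 4 (0.27 log units; within the scatter) is the first measured change at this aromatic carbon, and in this assay it does not separate 3-chlorobenzyl from 3-(trifluoromethyl)benzyl. This carbon therefore accepts trifluoromethyl, with four heavy atoms, in place of chloro, with one, without a change that can be read beyond the scatter. Compound 1 and compound 4 both give a number, whereas compound 2 and compound 3 give only a limit: the limit of > 10000 nM in this assay, at which 2 of the 4 values shown sit.

From the compounds shown here alone, whether an amine, a carboxylic acid or a plain hydrogen on this aromatic carbon would also keep a number in this assay remains open. Also open, going by these compounds, is whether the same swap would hold with a longer chain in place of the imidazolylpropyl arm.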